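Swapping nitro for bromo on the phenyl of compound 1

The compounds below may be only part of what the source reports. "The series", "measured", "known", "first", "only" and "open" are said of these compounds alone.

Measured compounds:
compound 1 `O=Cc1c(-c2ccc([N+](=O)[O-])cc2)nc2sc(Cc3ccccc3)nn12`: 3700 nM
compound 2 `O=[N+]([O-])c1ccc(-c2nc3sc(Cc4ccccc4)nn3c2Br)cc1`: 3700 nM

In a functional assay on cells (Cancer cell lines, Homo sapiens) for inhibition (a lower number here means a stronger inhibitor of growth, a higher number a weaker inhibitor of growth), compound 1 gives 3700 nM. Compound 2 differs from it only by bromo in place of formyl on an aromatic carbon, and in this assay compound 2 gives 3700 nM; the step of no change at the digits printed from compound 1 to compound 2 (within the scatter) stays within the scatter, so compound 1 stands level with compound 2 on the numbers shown. Compound 3 `O=Cc1c(-c2ccc(Br)cc2)nc2sc(Cc3ccccc3)nn12` is compound 1 with a different change: bromo in place of nitro on an aromatic carbon. Within the data shown here, the only recorded step leaves the nitro group untouched and shows no change, so it bears on this new change only loosely. There is thus no ground for expecting a shift beyond the scatter in this assay in either direction. Compound 3 is therefore estimated at 3700 nM, with a range from 1200 nM to 12000 nM. This corresponds to an expected step of no change at the digits printed from compound 1 to compound 3 (within the scatter).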

Compound 3, concentration for 50% growth inhibition: 3200 nM
Compound 3: the middle estimate sits 1.2-fold (0.06 log units) above what was measured; measured number inside the range.
By their numbers in this assay, from the lowest: compounds 3, 1 and 2 (each within the scatter of the next).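

In this assay, the earlier step concerned only the formyl place, whereas this one shows that the aromatic carbon para to a large group also accepts a change: bromo in place of nitro gives a 1.2-fold lower number from compound 1 to compound 3 (0.06 log units; within the scatter). That exchange takes away the hydrogen-bond acceptors and the double bond counted for nitro, and also two of its heavy atoms, yet the number stays within the scatter, so for this pair neither feature of nitro is needed to hold growth inhibition at this level. Nothing measured alongside these compounds accounts for this result.

As far as these compounds go, it remains open whether an amine or a carboxylic acid at this same carbon would leave the number as flat as bromo does. Also open, from the compounds shown here alone, is whether bromo at both changed places, replacing formyl and nitro together, would hold the level seen here.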